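A few compounds are considered here, and "the series" means these few. Any claim that something is new, unique, unknown or untested is made for them only; others in the source may bear on it.

Two compounds measured in a functional assay for inhibition of Polyunsaturated fatty acid 5-lipoxygenase (Homo sapiens) (on this read-out lower numbers stand for stronger inhibition and higher numbers for weaker inhibition), set the frame. Compound 1 `C=CCC(O/N=C(\C)C(=O)O)c1ccc(OCc2ccc3ccccc3n2)cc1` carries a short unsaturated chain next to the oxime ether, and in this assay compound 1 gives 142 nM. Compound 2 `CCCCC(CCCC)C(O/N=C/C(=O)O)c1ccc(OCc2ccc3ccccc3n2)cc1` carries a longer branched chain at the same place and an oxime bearing hydrogen rather than methyl, and in this assay compound 2 gives 10 nM. Compound 2 thus holds the lowest number of the two, and its gap to compound 1 lies beyond the usual scatter, though the two differ in two places at once, so no single change can be credited.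

Compound 3 `CCCCC(CCCC)C(O/N=C(\C)C(=O)O)c1ccc(OCc2ccc3ccccc3n2)cc1` keeps the branched chain of compound 2 and changes only the oxime end: a group of 6 heavy atoms (3 carbon, 1 nitrogen, 2 oxygen; no ring) in place of a group of 5 heavy atoms (2 carbon, 1 nitrogen, 2 oxygen; no ring), on an oxygen on a saturated carbon, in words, a group of 6 heavy atoms (3 carbon, 1 nitrogen, 2 oxygen; no ring) in place of a group of 5 heavy atoms (2 carbon, 1 nitrogen, 2 oxygen; no ring), on an oxygen on a saturated carbon. In effect the oxime gains the methyl already seen in compound 1. Going by the values given here, no measured pair differs only in this way, so the size of such a step in this assay is unknown; a step within the scatter, in either direction, seems most likely. Compound 3 is therefore expected to give about 12 nM in this assay, within a range of 4 nM to 40 nM. The expected step is a 1.2-fold higher number from compound 2 to compound 3 (0.08 log units; within the scatter).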

Compound 3, half-maximal inhibitory concentration: 14 nM
Compound 3: the middle estimate sits 1.2-fold (0.07 log units) below what was measured, and the stated range covers the measured number.
By their numbers in this assay, from the lowest: compounds 2 and 3 (each within the scatter of the next); then compound 1.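

Adding the methyl to the oxime end while the 1-butylpentyl chain stays fixed gives a 1.4-fold higher number from compound 2 to compound 3 (0.15 log units; within the scatter) in this assay, so with this chain in place, the two oxime ends cannot be told apart. With the oxime end held fixed, 1-butylpentyl in place of allyl on a saturated chain carbon bound to an aromatic carbon and an oxygen on an unsaturated carbon gives a 10-fold lower number from compound 1 to compound 3 (1.01 log units; beyond the scatter) and this large step shows that the chain alone can account for a change beyond the scatter, which the two-place difference between the first two compounds could not show. Nothing available here speaks to the reason for the size of either step.

As far as these compounds go, with only allyl and 1-butylpentyl to compare, it remains open whether length or branching matters more, and whether an unbranched hexyl chain or a cyclohexyl ring would behave like 1-butylpentyl. From the compounds shown here alone, it also remains open whether the oxime change would stay this small on the allyl compound, and whether an ethyl group at the oxime end, or an amide in place of the carboxylic acid, would leave the number unchanged.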